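The compounds below may be only part of what the source reports. "The series", "measured", "known", "first", "only" and "open" are said of these compounds alone.

Of the compounds shown here, three built on one shared core have been tested in a toxicity assay on L02 cells (Homo sapiens) for inhibition, read by MTT assay, with a stated time of 48 h; on this read-out lower numbers stand for stronger inhibition and higher numbers for weaker inhibition. Compound 1 `CCCCC(=O)Nc1ccc(N2CCN(c3ccc(OC[C@@H]4CO[C@@](Cn5cncn5)(c5ccc(Cl)cc5Cl)O4)cc3)CC2)cc1` carries a butyl group on the carbonyl carbon of its amide. In this assay compound 1 gives > 50000 nM, which is a limit of the assay rather than a number. Compound 2 `O=C(CC1CCOCC1)Nc1ccc(N2CCN(c3ccc(OC[C@@H]4CO[C@@](Cn5cncn5)(c5ccc(Cl)cc5Cl)O4)cc3)CC2)cc1` differs from compound 1 by oxan-4-yl in place of propyl on a saturated chain carbon bound to a carbonyl carbon. In this assay compound 2 gives > 50000 nM, again a limit. Compound 3 `O=C(Nc1ccc(N2CCN(c3ccc(OC[C@@H]4CO[C@@](Cn5cncn5)(c5ccc(Cl)cc5Cl)O4)cc3)CC2)cc1)C(/C=C/Cl)C/C=C/C(F)(F)F` carries 1-(2-chloroethenyl)-5,5,5-trifluoropent-3-en-1-yl on the carbonyl carbon. In this assay compound 3 gives > 50000 nM, which is also a limit, so compound 3 stands at the same limit as the other two. Among the measured compounds shown here, the steps a step that the two limits leave unreadable from compound 1 to compound 2, a step that the two limits leave unreadable from compound 1 to compound 3 and a step that the two limits leave unreadable from compound 2 to compound 3 cannot be read for size, and the only evidence available is the limit of > 50000 nM in this assay, at which 3 of the 3 values shown sit.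

Compound 4 `O=C(Nc1ccc(N2CCN(c3ccc(OC[C@@H]4CO[C@@](Cn5cncn5)(c5ccc(Cl)cc5Cl)O4)cc3)CC2)cc1)c1cccc(F)c1` is not yet measured. Its change from compound 3 is 3-fluorophenyl in place of 1-(2-chloroethenyl)-5,5,5-trifluoropent-3-en-1-yl on a carbonyl carbon. Because every measured step sits at the limit of > 50000 nM in this assay, at which 3 of the 3 values shown sit, no direction beyond the scatter can be read for this change. The step of a number no higher from compound 3 to compound 4 (the limit leaves the size open) is therefore expected to be none beyond the scatter. Compound 4 is expected to give 50000 nM in this assay, within a range from 20000 nM to 100000 nM, and most likely to be reported again only as a limit.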

Compound 4, half-maximal inhibitory concentration: > 50000 nM
Compound 4: only a limit was reported; the forecaster's own chance of this, stated with the estimate: 80%; the middle value lies on the limit itself.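

In this assay compound 4 gives > 50000 nM, which is a limit of the assay and not a number. The steps linking compound 4 to compound 1, compound 2 and compound 3 therefore cannot be read for size: the limit of > 50000 nM in this assay, at which 4 of the 4 values shown sit.

Going by these compounds, what stays open is whether the different groups on the carbonyl carbon change inhibition at all, and at what concentration any of these four compounds would reach half-maximal inhibition.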